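The source may report more compounds than this note shows. Statements on the series, on what has been measured and on what is new or still open speak of the compounds shown alone.

Measured compounds:
- compound 1, `N#C/N=C(/NCCCCc1c[nH]cn1)NCCCc1ccc(F)cc1`; in an in vitro functional assay on Sf9 cells for antagonist activity at histamine H2 receptor (Homo sapiens) (on this read-out lower numbers stand for lower potency and higher numbers for higher potency (the scale is a negative logarithm)), compound 1 gives 5.28
- compound 2, `N#C/N=C(/NCCCCc1c[nH]cn1)NCCCc1cccnc1`; compound 2 gives 5.92

Going by the values given here, of these two numbers, compound 2 holds the higher one; the one step seen so far runs a number 0.64 log units higher from compound 1 to compound 2 (beyond the scatter) and is a modest gain that exceeds the scatter. The next compound, compound 3 with structure `CCN/C(=N\C#N)NCCCCc1c[nH]cn1`, differs from compound 2 by hydrogen in place of (pyridin-3-yl)methyl on a saturated chain carbon, two bonds along the chain from an amine nitrogen, so the whole aromatic arm is cut away and only a short saturated chain remains on that amine nitrogen.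

Among the compounds with values here, no measured step bears directly on this change: the only step seen exchanges one aromatic ring for another while keeping the arm, whereas here the arm is removed altogether. The data therefore give no direct reference for its size. Since both measured compounds carry an aromatic ring in this arm, and the ring exchange alone moved the number beyond the scatter, compound 3 is expected to lose rather than gain, with a step of a number 0.92 log units lower from compound 2 to compound 3 (beyond the scatter) in this assay. Compound 3 is estimated at 5, within a range of 4.3 to 5.7.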

Compound 3, negative logarithm of the antagonist equilibrium constant: < 5
Compound 3 ended at the assay's limit; the forecaster's own chance of this, stated with the estimate: 10%; the middle value sits exactly at the limit.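

In this assay compound 3 gives < 5 as a limit of the assay and not a number: the limit of < 5 in this assay, at which 1 of the 3 values shown sits.

Removing the whole arm shows what the ring exchange could not, that the arm itself counts at this position when it carries pyridin-3-yl: hydrogen in place of (pyridin-3-yl)methyl gives a number at least 0.92 log units lower from compound 2 to compound 3 (beyond the scatter). The same cut on the other arm gives a number at least 0.28 log units lower from compound 1 to compound 3 (that floor lies within the scatter), so the compounds shown do not establish that the 4-fluorobenzyl arm adds anything over the short saturated chain, and the gain from an aromatic ring in this arm is firm only for pyridin-3-yl.

Going by these compounds, how far compound 3 really lies under the limit stays open, and with it the full size of both steps. Also open, on these data alone, is how a plain phenyl ring, a pyridin-2-yl or pyridin-4-yl ring, or a longer or shorter chain carrying the ring would read at this position in this assay.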